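Bromo added to the fused ring of compound 2

The source may report more compounds than this note shows. Statements on the series, on what has been measured and on what is new or still open speak of the compounds shown alone.

Compound 1: `O=C(Nc1ccc(F)cc1)Nc1nc(-c2cc3ccccc3o2)cs1` — 1130 nM
Compound 2: `COc1ccc(NC(=O)Nc2nc(-c3cc4ccccc4o3)cs2)cc1` — 17400 nM

Of the compounds shown here, two have been measured in a physicochemical assay, with a stated time of 6 min; on this read-out higher numbers stand for weaker inhibition and lower numbers for stronger inhibition. Compound 1 gives 1130 nM, and compound 2 gives 17400 nM. Between them there is one step: a 15-fold higher number from compound 1 to compound 2 (1.19 log units; beyond the scatter). Compound 2 therefore stands highest of the two numbers, and its nearest neighbour, compound 1, sits well below it, by a margin beyond the scatter.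

Compound 3 is `COc1ccc(NC(=O)Nc2nc(-c3cc4cc(Br)ccc4o3)cs2)cc1`; it is not yet measured. It differs from compound 2 in one place: bromo in place of hydrogen on an aromatic carbon. Among the compounds with values here, the single measured step, the one from compound 1 to compound 2, concerns a different group at a different place, so no measured step bears on this change. There is nothing in the data to suggest a shift in this assay in either direction, and a step of a 1.2-fold lower number from compound 2 to compound 3 (0.06 log units; within the scatter) is expected, which is to say none beyond the scatter. Compound 3 is thus estimated at 15000 nM, with a range from 5000 nM to 45000 nM.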

Compound 3, half-maximal inhibitory concentration: > 200000 nM
Compound 3: a limit, no number (the forecaster's own chance of this, stated with the estimate: 5%); middle value at least 13-fold (1.12 log units) away from the limit.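

In this assay, putting bromo in place of hydrogen on the fused ring gives an at least 11-fold higher number from compound 2 to compound 3 (1.06 log units; beyond the scatter), a large move toward weaker inhibition. On these data alone, compound 3 is recorded only as a limit of the assay and not as a number, so the true size of this step stays unknown, and it may be larger than printed: the limit of > 200000 nM in this assay, at which 1 of the 3 values shown sits. Within the data shown here, the earlier compounds showed a change only at the fluoro or methoxy group on the other side of the shared core, whereas this result is the first sign that the read-out also responds to the fused ring, and that a single added bromine atom on an aromatic carbon there is enough for a step beyond the scatter.

The compounds shown leave open whether this step belongs to bromo itself or would follow any group at this place, which a chloro, an amine or a carboxylic acid on the same carbon could help to tell apart. They also leave open whether bromo at this place would give a similar step on the core of compound 1, which carries fluoro rather than methoxy.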